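The source may hold more compounds than are shown below. What is called first, only, known or untested is meant among the compounds shown, and "the series" means these compounds.

Working notes on the series. The measured set so far holds compound 1 `O=C(/C(=C\c1c[nH]c2ccc(Br)cc12)SCc1ccc(F)cc1)c1ccc(Cl)cc1` and compound 2 `O=C(/C(=C\c1c[nH]c2ccc(Br)cc12)SCc1ccc(Cl)cc1Cl)c1ccc(Cl)cc1`. In a functional assay on DU-145 cells (Homo sapiens) for inhibition, read by trypan blue exclusion, with a stated time of 96 h (on this read-out higher numbers stand for weaker inhibition of growth and lower numbers for stronger inhibition of growth), compound 1 gives 50000 nM, the highest of the two numbers, and compound 2 gives 10000 nM. Going by the values given here, the one step recorded between them, a 5.0-fold lower number from compound 1 to compound 2 (0.70 log units; beyond the scatter), concerns the group on the saturated chain carbon bound to the sulfur and leaves the rest of the shared core untouched.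

The next compound is compound 3 `Cc1ccc(/C=C(/SCc2ccc(F)cc2)C(=O)c2ccc(Cl)cc2)s1`. Its difference from compound 1 is 5-methylthiophen-2-yl in place of 5-bromo-1H-indol-3-yl on a double-bonded chain carbon bound to a double-bonded chain carbon. Among the compounds with values here, no measured pair changes this part of the core, so the step from compound 1 to compound 2 does not bear on it, and there is no basis in the numbers to expect a shift in this assay in either direction beyond the scatter. The number for compound 3 is therefore estimated at 50000 nM, with a range from 12000 nM to 150000 nM, which means an expected step of no change at the digits printed from compound 1 to compound 3 (within the scatter).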

Compound 3, concentration for 50% growth inhibition: > 100000 nM
Compound 3: no number, only a limit; the forecaster's own chance of this, stated with the estimate: 30%; at least 2.0-fold (0.30 log units) between middle value and limit.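

In this assay compound 3 reads > 100000 nM, which is a limit of the assay and not a number. Going by these compounds alone, this is the first change on the double-bonded chain carbon, and exchanging 5-bromo-1H-indol-3-yl for 5-methylthiophen-2-yl gives an at least 2.0-fold higher number from compound 1 to compound 3 (0.30 log units; that floor lies within the scatter), so the exchange brings no stronger inhibition of growth, while the floor alone does not establish a weaker one. The true size of the step stays unread: the limit of > 100000 nM in this assay, at which 1 of the 3 values shown sits.

Left open is which part of the exchange matters, as the two groups differ at once in bromine, in ring count and in the hydrogen-bond donor. Also open, on these data alone, is whether a 1H-indol-3-yl group without the bromine, or a 4-aminophenyl group, on this double-bonded chain carbon would keep the reading of compound 1.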